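From compound 3 to compound 4: changing the amine

The source may report more compounds than this note shows. Statements on the series, on what has been measured and on what is new or still open speak of the compounds shown alone.

Among the measured compounds shown here, in a functional assay on MCF7 cells (Homo sapiens) for antiproliferative activity (on this read-out higher numbers stand for weaker inhibition and lower numbers for stronger inhibition), compound 3 (`CC(C)=CCc1cc(C(=O)Nc2cc3ccc(OCCCN(C)C(C)C)c(C)c3oc2=O)ccc1O`) gives 1050 nM as the lowest number so far. Compound 1 (`CCN(C)CCCOc1ccc2cc(NC(=O)c3ccc(O)c(CC=C(C)C)c3)c(=O)oc2c1C`) gives 2190 nM and compound 2 (`CCN(CC)CCCOc1ccc2cc(NC(=O)c3ccc(O)c(CC=C(C)C)c3)c(=O)oc2c1C`) gives 6390 nM on the same read-out. Compound 4 (`CC(C)=CCc1cc(C(=O)Nc2cc3ccc(OCCCNC4CCCCC4)c(C)c3oc2=O)ccc1O`) carries cyclohexylamino in place of isopropyl(methyl)amino on a saturated chain carbon, three bonds along the chain from an oxygen on an aromatic ring. Three measured amine changes bear on this (a 2.9-fold higher number from compound 1 to compound 2 (0.47 log units; beyond the scatter) and a 2.1-fold lower number from compound 1 to compound 3 (0.32 log units; beyond the scatter) and a 6.1-fold lower number from compound 2 to compound 3 (0.78 log units; beyond the scatter)) and all are modest, running both ways. For the measured compounds named here, no measured compound carries cyclohexylamino, so no firm direction and no step beyond the scatter is expected in this assay here. The expected step is small (a 1.4-fold higher number from compound 3 to compound 4 (0.15 log units; within the scatter)) on this estimate. For compound 4 the estimated value is 1500 nM with an expected range from 450 nM to 5000 nM for now.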

Compound 4, half-maximal inhibitory concentration: 1070 nM
The estimate for compound 4 lay 1.4-fold (0.15 log units) above the measured number; the measured number falls inside the stated range.
By their numbers in this assay, from the lowest: compounds 3 and 4 (each within the scatter of the next); then compound 1; then compound 2.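

In this assay, cyclohexylamino, with its six-membered carbon ring and one hydrogen-bond donor, gives a 1.0-fold higher number from compound 3 to compound 4 (0.01 log units; within the scatter) against isopropyl(methyl)amino, so this chain end accepts the ring and the donor without a step beyond the scatter. Against the two remaining amines it gives a 6.0-fold lower number from compound 2 to compound 4 (0.78 log units; beyond the scatter) and a 2.0-fold lower number from compound 1 to compound 4 (0.31 log units; beyond the scatter) on the same read-out, which places cyclohexylamino with isopropyl(methyl)amino among the four amines shown. No evidence at hand accounts for these steps. Still open, from the compounds shown here alone, is how a morpholine or piperidine ring at this chain end reads, and how a longer chain carrying cyclohexylamino reads.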